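Swapping the Amine Substituent: Expected Tolerance of Compound 4

This account rests on a few compounds, and the source may have more. Where it says the series, first, only, none or still open, it means among the compounds named here.

Of the compounds shown here, three sharing one core have been measured in an ADME assay on A549 cells (Homo sapiens) for cytotoxicity, read by resazurin assay, with a stated time of 48 h; a higher number here means that more compound is tolerated, a lower number that less compound is tolerated. Compound 1 `CC1(Nc2ccc(NC(=O)c3cc(Cl)ccc3O)c(Cl)c2)CCCC1` gives 157000 nM, the highest of the three numbers. Compound 3 `COc1ccc(CNc2ccc(NC(=O)c3cc(Cl)ccc3O)c(Cl)c2)cc1` gives 80700 nM, and compound 2 `O=C(Nc1ccc(NCc2ccc(C(F)(F)F)cc2)cc1Cl)c1cc(Cl)ccc1O` gives 62700 nM. The step of a 1.9-fold lower number from compound 1 to compound 3 (0.29 log units; within the scatter) lies within the scatter, while compound 2 sits furthest from compound 1, beyond the scatter. The step of a 1.3-fold higher number from compound 2 to compound 3 (0.11 log units; within the scatter) also lies within the scatter.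

Compound 4 `O=C(Nc1ccc(N(CCCO)CCCO)cc1Cl)c1cc(Cl)ccc1O` has not yet been measured. It differs from compound 1 as follows: bis(3-hydroxypropyl)amino in place of (1-methylcyclopentyl)amino on an aromatic carbon. For the measured compounds named here, the step that bears most directly on this change is the one from compound 1 to compound 3, where the same amine nitrogen carried a different group and the number moved only within the scatter. The step from compound 2 to compound 3 touches another part of the molecule and is also within the scatter. Nothing among these three compounds points to a large shift in either direction when the group on that nitrogen is exchanged.

The expected step is therefore a 1.0-fold lower number from compound 1 to compound 4 (0.02 log units; within the scatter), within the scatter. For compound 4 the estimate in this assay is 150000 nM, with a range from 60000 nM to 400000 nM.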

Compound 4, half-maximal cytotoxic concentration: 114000 nM
Beside the measured number, compound 4's estimate is 1.3-fold (0.12 log units) above it; the range from low to high includes it.
By their numbers in this assay, from the lowest: compounds 2, 3, 4 and 1 (each within the scatter of the next, the first and the last beyond it).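

In this assay the exchange of (1-methylcyclopentyl)amino for bis(3-hydroxypropyl)amino on this aromatic carbon gives a 1.4-fold lower number from compound 1 to compound 4 (0.14 log units; within the scatter) and so leaves compound 1 and compound 4 indistinguishable in this read-out. The earlier compounds shown here each carried a single ring-bearing group on this nitrogen, whereas compound 4 carries two open chains with no ring, ending in hydroxyl groups, and adds hydrogen-bond donors and acceptors, so the position has now taken a much different substituent with no step beyond the scatter. Nothing measured here accounts for this result at this position.

The compounds shown leave open whether one of the two chains alone, as a single 3-hydroxypropyl group on the nitrogen, would give a number in the same range, and whether a longer chain would do so. They also leave open what a carboxylic acid or an amine at the end of these chains would do, since every group shown on this nitrogen carries no net charge.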